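Benzyl variation on a triazole-linked chromone ether scaffold

A few compounds are considered here, and "the series" means these few. Any claim that something is new, unique, unknown or untested is made for them only; others in the source may bear on it.

Compound 1 `Cc1ccc(Cn2cc(COc3ccc4c(=O)ccoc4c3)nn2)cc1` gives in a functional assay on MDA-MB-231 cells (Homo sapiens) for cytotoxicity, read by MTT assay, with a stated time of 48 h (on this read-out higher numbers stand for weaker inhibition and lower numbers for stronger inhibition), only the limit > 100000 nM.
Compound 2 `O=c1ccoc2cc(OCc3cn(Cc4cccc(Cl)c4)nn3)ccc12` gives in this assay only the limit > 100000 nM.
Compound 3 `C#CCOc1ccc2c(=O)ccoc2c1` gives in this assay only the limit > 100000 nM.

Compound 2 therefore stands at a limit, not at a number, and the same holds for every value shown: all three sit at the limit of > 100000 nM in this assay, at which 3 of the 3 values shown sit. Going by the values given here, the one step between measured compounds, a step that the two limits leave unreadable from compound 1 to compound 2, cannot be read because both of its ends are limits, so nothing in the measured set tells how a change on the benzyl group moves this assay.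

Compound 4 `COc1ccc(Cn2cc(COc3ccc4c(=O)ccoc4c3)nn2)cc1` differs from compound 2 in one place: 4-methoxyphenyl in place of 3-chlorophenyl on a saturated chain carbon bound to an aromatic nitrogen.

Among the compounds with values here, the only step that bears on this change is a step that the two limits leave unreadable from compound 1 to compound 2, which gave no readable size, and with all three values at the limit of > 100000 nM in this assay, at which 3 of the 3 values shown sit, there is no ground for expecting a step beyond the scatter in either direction. Compound 4 is estimated at 120000 nM, with a range from 30000 nM to 400000 nM, and it is expected most likely to return only a limit again. The step that the limit leaves unreadable from compound 2 to compound 4 is thus expected to be none beyond the scatter.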

Compound 4, half-maximal inhibitory concentration: > 100000 nM
Compound 4: no number, only a limit (the forecaster's own chance of this, stated with the estimate: 85%); the middle value is on the limit's open side.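

Compound 4 gives only the limit > 100000 nM in this assay and no number. Going by these compounds alone, compound 1 and compound 2 also stand at limits, so no step to compound 4 can be read. The compounds shown leave open whether any change on the benzyl group would give a number in this assay at all.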